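This account rests on a few compounds, and the source may have more. Where it says the series, first, only, none or still open, it means among the compounds named here.

Compounds measured so far:
Compound 1, `COC(=O)c1cc(=O)c2c(OC)cc(OC)cc2n1C`: > 37900 nM
Compound 2, `COc1ccc(-c2cc(=O)c3c(OC)cc(OC)cc3n2S(=O)(=O)c2ccc([N+](=O)[O-])cc2)cc1`: 17100 nM

In a functional assay on SUP-B15 cells (Homo sapiens) for antiproliferative activity, with a stated time of 72 h (on this read-out higher numbers stand for an effect only at larger amounts of compound and lower numbers for an effect already at smaller amounts), compound 1 reached only a limit of the assay, > 37900 nM, not a number. In this assay compound 2 gives 17100 nM. Among the measured compounds shown here, that makes compound 2 the holder of the only number so far, since the one other result is a limit (the limit of > 37900 nM in this assay, at which 1 of the 2 values shown sits), so there is no measured pair from which the effect of any single structural change could be read.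

Compound 3, `COc1ccc(-c2cc(=O)c3c(OC)cc(OC)cc3n2S(=O)(=O)c2ccc(C)cc2)cc1`, has not yet been measured. It differs from compound 2 in one place: methyl in place of nitro on an aromatic carbon. For the measured compounds named here, with no measured step of this kind to lean on, the change from compound 2 to compound 3 is expected to move the read-out by little, the step of a 1.3-fold higher number from compound 2 to compound 3 (0.11 log units; within the scatter) probably staying within the usual scatter, with a weak lean toward an effect only at somewhat larger amounts. Compound 3 is therefore estimated at 22000 nM in this assay, with a likely range from 8000 nM to 50000 nM.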

Compound 3, half-maximal effective concentration: > 44800 nM
Compound 3: only a limit was reported; the forecaster's own chance of this, stated with the estimate: 30%; middle value at least 2.0-fold (0.30 log units) from the limit.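

In this assay, among the compounds shown here, replacing the nitro of the 4-nitrophenyl group with methyl gives an at least 2.6-fold higher number from compound 2 to compound 3 (0.41 log units; beyond the scatter), the first single change in this set whose effect can be read. For compound 3 the result is a limit of the assay and not a number, so this step has only a lower bound: the limit of > 44800 nM in this assay, at which 1 of the 3 values shown sits. With the rest of the structure unchanged, this shows that the group on this aromatic carbon, para to a large group, is not a bystander: the read-out responds to the change from nitro to methyl, and the only measured number among these compounds belongs to the nitro compound.

One pair cannot show which feature of the nitro group matters, or how far the read-out moves beyond the limit reached by compound 3. An amine, a nitrile or a carboxylic acid on the same carbon, or a plain hydrogen there, would show whether nitro is special or methyl is simply a poor fit for the read-out, and compound 1 cannot help, as it differs from the others in more than one place.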